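The source may report more compounds than this note shows. Statements on the series, on what has been measured and on what is new or still open speak of the compounds shown alone.

Measured in a functional assay on SK-MEL-147 cells (Homo sapiens) for cytotoxicity, read by MTT assay, with a stated time of 24 h; a higher number here means that more compound is needed for the effect, a lower number that less compound is needed:
- Compound 1 `CCOC(=O)c1cc([Se]c2ccc(F)cc2)c2cc(OC)ccc2n1`: > 150000 nM, a limit of the assay and not a number
- Compound 2 `CCOC(=O)c1cc([Se]c2ccccc2)c2cc(OC)ccc2n1`: 33000 nM

Among the measured compounds shown here, compound 2 therefore holds the only actual number so far. For the measured compounds named here, the one other reading is the limit of > 150000 nM in this assay, at which 1 of the 2 values shown sits.

Compound 3 `COc1ccc2nc(-c3c(C)cccc3C)cc([Se]c3ccccc3)c2c1` is still unmeasured. It carries 2,6-dimethylphenyl in place of ethoxycarbonyl on an aromatic carbon.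

Going by the values given here, the only measured step, an at least 4.5-fold lower number from compound 1 to compound 2 (0.65 log units; beyond the scatter), is a swap of hydrogen for fluoro elsewhere on the molecule, so it gives no direction for this change. No step beyond the scatter in this assay can be expected with confidence.

The estimated step is a 1.1-fold higher number from compound 2 to compound 3 (0.03 log units; within the scatter). For compound 3 the expected value is 35000 nM, with an estimated range from 9000 nM to 140000 nM.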

Compound 3, half-maximal effective concentration: 37300 nM
For compound 3 the middle estimate is 1.1-fold (0.03 log units) below the measured one, within the range that was stated.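

Among the compounds shown here, the earlier pair changed only a fluoro elsewhere on the molecule, so this is the first view of the position next to the ring nitrogen. In this assay, swapping ethoxycarbonyl for the all-carbon 2,6-dimethylphenyl gives a 1.1-fold higher number from compound 2 to compound 3 (0.05 log units; within the scatter), so two very different groups here read alike. For the compounds shown here, nothing measured so far offers a reason for this.

Still open, going by these compounds, is how a carboxylic acid or an amine at this position would read. Also open, on these data alone, is whether plain phenyl, without the two methyl groups, would read the same.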